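Swapping a Phenyl for a Propyl on a Shared Core

The source may report more compounds than this note shows. Statements on the series, on what has been measured and on what is new or still open speak of the compounds shown alone.

Compound 2 `N#C[Se]c1ccc(NC(=O)OCc2ccccc2)cc1` is the starting point here. For the measured compounds named here, in a functional assay on HTB-54 cells (Homo sapiens) for cytotoxicity, read by MTT assay, with a stated time of 72 h (a lower number here means a stronger inhibitor of growth, a higher number a weaker inhibitor of growth), compound 2 gives 27600 nM, the highest of the three numbers measured so far, though all three sit close together. Its nearest neighbour is compound 1 `N#C[Se]c1ccc(NC(=O)OCc2ccc([N+](=O)[O-])cc2)cc1`, which gives 22900 nM in this assay; the step of a 1.2-fold higher number from compound 1 to compound 2 (0.08 log units; within the scatter) shows how little separates them. Compound 3 `N#C[Se]c1ccc(NC(=O)Oc2ccc(Cl)cc2)cc1` gives 13800 nM in this assay, and its gap to compound 2 is also within the scatter, so none of the three can be called the strongest or the weakest.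

Compound 4 `CCCCOC(=O)Nc1ccc([Se]C#N)cc1` has not yet been measured. It differs from compound 2 in one place: propyl in place of phenyl on a saturated chain carbon bound to an oxygen next to a carbonyl group. Going by the values given here, no measured step bears directly on this change. Among the compounds with values here, the only step on record, a 1.2-fold higher number from compound 1 to compound 2 (0.08 log units; within the scatter), concerns a change on an aromatic ring, and compounds 1, 2 and 3 all remain within the scatter of one another. The measured values therefore give no reason to expect a step beyond the scatter in either direction in this assay. The step expected is a 1.1-fold lower number from compound 2 to compound 4 (0.04 log units; within the scatter). Compound 4 is estimated at 25000 nM in this assay, with a range from 10000 nM to 60000 nM.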

Compound 4, concentration for 50% growth inhibition: 17200 nM
Compound 4: middle estimate off by 1.5-fold (0.16 log units), on the high side; the measured number falls inside the stated range.
By their numbers in this assay, from the lowest: compounds 3, 4, 1 and 2 (each within the scatter of the next).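

In this assay, propyl in place of phenyl on a saturated chain carbon bound to an oxygen next to a carbonyl group gives a 1.6-fold lower number from compound 2 to compound 4 (0.21 log units; within the scatter). The earlier step exchanged a group on the aromatic ring of this side of the molecule and left the ring in place, whereas this change removes the phenyl altogether, and the number still stays within the scatter, so an aromatic ring at this place is not needed for a number in this range. No measurement of any property of these two groups accompanies the step, so what lies behind the result cannot be said.

Still open, going by these compounds, is how far this place accepts other groups: a longer chain such as hexyl, a branched one such as tert-butyl, or a chain ending in an amine or a carboxylic acid might stay within the scatter or might move the number well beyond it. Also open, on these data alone, is whether the same exchange of phenyl for propyl would give a similar step on a different core or in other cell types.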